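Swapping the benzyl arm on a weakly active analogue

The compounds below may be only part of what the source reports. "The series", "measured", "known", "first", "only" and "open" are said of these compounds alone.

Compound 1 `Nc1nc(NCc2cccs2)nc2sc(-c3ccco3)nc12`: 75 nM
Compound 2 `COc1cccc(CNc2nc(N)c3nc(-c4ccc(C)o4)sc3n2)c1`: 120 nM
Compound 3 `COc1cccc(CNc2nc(N)c3nc(-c4cccs4)sc3n2)c1`: 2770 nM

All three were tested in a functional assay on CHO cells for agonist activity at adenosine receptor A2b (Homo sapiens), read by scintillation counting and cAMP accumulation, with a stated time of 150 min, in the presence of a further agent that is not named here; a higher number here means a weaker inhibitor, a lower number a stronger inhibitor. Compound 3 has the highest number of the three: the nearest is compound 2, and the step of a 23-fold higher number from compound 2 to compound 3 (1.36 log units; beyond the scatter) shows how far apart they lie, while compound 1 sits further still. Among the measured compounds shown here, the only single change measured here is that step, and it concerns the five-membered ring on the shared core, not the arm attached to the amine.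

Compound 4 `Nc1nc(NCc2cccs2)nc2sc(-c3cccs3)nc12` is the next compound, and it differs from compound 3 as follows: thiophen-2-yl in place of 3-methoxyphenyl on a saturated chain carbon bound to a nitrogen on an aromatic ring. For the measured compounds named here, no measured pair isolates this change. Compound 1 and compound 2 carry the two different arms, but they also differ in the ring on the core, so only their values can be compared: in this assay compound 1 gives 75 nM and compound 2 gives 120 nM, two numbers within the usual scatter of each other. That offers mild support for the arm swap having little effect on its own, though it is not a clean comparison.

Compound 4 is therefore expected to stay close to compound 3, at about 2200 nM, with a range from 600 nM to 8000 nM. This amounts to an expected step of a 1.3-fold lower number from compound 3 to compound 4 (0.10 log units; within the scatter), not beyond the scatter.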

Compound 4, half-maximal inhibitory concentration: 547 nM
Beside the measured number, compound 4's estimate is 4.0-fold (0.60 log units) above it, and the stated range ends above it.
By their numbers in this assay, from the lowest: compounds 1 and 2 (each within the scatter of the next); then compound 4; then compound 3.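

In this assay, the arm on the amine can now be read alone, with thiophen-2-yl on the core held fixed: thiophen-2-yl in place of 3-methoxyphenyl on a saturated chain carbon bound to a nitrogen on an aromatic ring gives a 5.1-fold lower number from compound 3 to compound 4 (0.70 log units; beyond the scatter) and so shows that this position does respond, which compound 1 and compound 2, differing in two places, could not show. With the thiophen-2-yl arm held fixed, the ring on the core can also be read alone, as thiophen-2-yl in place of furan-2-yl gives a 7.3-fold higher number from compound 1 to compound 4 (0.86 log units; beyond the scatter) and thus moves the number in the same direction as a 23-fold higher number from compound 2 to compound 3 (1.36 log units; beyond the scatter), the earlier step from a methylated furan. No measurement of any property of these groups is available to account for either new step.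

As far as these compounds go, whether the arm swap has a similar effect with furan-2-yl or 5-methylfuran-2-yl on the core remains open, as the swap has been isolated only with thiophen-2-yl there. It is also unknown how a plain phenyl, a pyridin-2-yl or a longer chain carrying the thiophen-2-yl would fare at this position.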